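The source may hold more compounds than are shown below. What is called first, only, known or untested is meant among the compounds shown, and "the series" means these compounds.

Compound 3 `O=C1C2CCCN2C(=O)N1CCN1CCN(c2ccc(F)cc2)CC1` belongs to a small set sharing one core. In an assay on isolated protein for binding affinity to Adrenergic receptor alpha-1 (Rattus norvegicus), read by radioligand binding (on this read-out lower numbers stand for stronger inhibition and higher numbers for weaker inhibition), compound 1 `O=C1C2CCCCN2C(=O)N1CN1CCN(c2cccc(C(F)(F)F)c2)CC1` gives > 1000 nM, which is a limit of the assay rather than a number. Compound 2 `O=C1C2CCCN2C(=O)N1CCN1CCN(c2cccc(Cl)c2)CC1` gives 500 nM. Compound 3 gives > 1000 nM, again a limit of the assay. Two of the three values thus sit at the same ceiling (the limit of > 1000 nM in this assay, at which 2 of the 3 values shown sit). Going by the values given here, the only single-site step, an at least 2.0-fold higher number from compound 2 to compound 3 (0.30 log units; that floor lies within the scatter), ends at that ceiling, so its true size is unknown. Compound 4 `O=C1C2CCCN2C(=O)N1CCN1CCN(c2ccc([N+](=O)[O-])cc2)CC1` differs from compound 3 by nitro in place of fluoro on an aromatic carbon. Among the compounds with values here, no measured step involves a nitro group, so only the standing of compound 3 at the limit guides the expectation. Compound 4 is therefore expected to move by about a step that the limit leaves unreadable from compound 3 to compound 4, likely remaining weak. Compound 4 is estimated at 2000 nM, within a range from 600 nM to 6000 nM.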

Compound 4, inhibition constant: > 10000 nM
Compound 4: only a limit was reported; the forecaster's own chance of this, stated with the estimate: 65%; middle value at least 5.0-fold (0.69 log units) away from the limit.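

In this assay, going by these compounds alone, 4-nitrophenyl in place of 3-chlorophenyl gives an at least 20-fold higher number from compound 2 to compound 4 (1.30 log units; beyond the scatter), the first step in this set to lie beyond the scatter. Compound 4 stands at a limit of its own: the limit of > 10000 nM in this assay, at which 1 of the 4 values shown sits. The step for nitro in place of fluoro cannot be read, so the set does not show whether nitro differs from fluoro at this position.

As far as these compounds go, it remains open how 4-nitrophenyl compares with 3-nitrophenyl on the same core. From the compounds shown here alone, it is also open whether an amine on this aromatic carbon, para to a large group, would give a readable value.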